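The compounds below may be only part of what the source reports. "The series", "measured", "known", "first", "only" and "open" are said of these compounds alone.

Among the measured compounds shown here, in an ADME assay on Vero cells (Chlorocebus sabaeus) for cytotoxicity, read by MTT assay, with a stated time of 72 h (on this read-out lower numbers stand for higher toxicity in this test and higher numbers for lower toxicity in this test), compound 2 (`COc1c(N2CCN(C/C(C)=N/NC(C)=O)C(C)C2)c(F)cc2c(=O)c(C(=O)O)cn(C3CC3)c12`) gives 707 ug/mL, the higher of the two numbers so far, while compound 1 (`COc1c(N2CCN(CCC(C)=O)C(C)C2)c(F)cc2c(=O)c(C(=O)O)cn(C3CC3)c12`) gives 9.84 ug/mL. For the measured compounds named here, the only measured step, a 72-fold higher number from compound 1 to compound 2 (1.86 log units; beyond the scatter), is large and beyond the scatter. Compound 3 (`CO/N=C(\C)CCN1CCN(c2c(F)cc3c(=O)c(C(=O)O)cn(C4CC4)c3c2OC)CC1C`) carries a group of 6 heavy atoms (4 carbon, 1 nitrogen, 1 oxygen; no ring) in place of a group of 7 heavy atoms (4 carbon, 2 nitrogen, 1 oxygen; no ring), on a saturated chain carbon bound to an amine nitrogen in a ring. That step ends in the group now leaving but starts from a different group, so it guides the size only loosely. A sizeable move toward lower numbers is expected, an estimated 7.9-fold lower number from compound 2 to compound 3 (0.90 log units; beyond the scatter). In this assay, compound 3 is expected at 90 ug/mL, with an estimated range from 15 ug/mL to 500 ug/mL.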

Compound 3, half-maximal cytotoxic concentration: 157 ug/mL
Compound 3: the middle estimate sits 1.7-fold (0.24 log units) below what was measured, and the stated range covers the measured number.
By their numbers in this assay, from the lowest: compound 1; then compound 3; then compound 2.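

In this assay, the change on this saturated chain carbon bound to an amine nitrogen in a ring gives a 4.5-fold lower number from compound 2 to compound 3 (0.65 log units; beyond the scatter), so a group with 0 hydrogen-bond donors can still reach a number far from that of compound 1. That distance is a 16-fold higher number from compound 1 to compound 3 (1.20 log units; beyond the scatter), so the higher numbers are not confined to the group with 1 hydrogen-bond donor in compound 2. Nothing measured here bears on why these numbers differ. The compounds shown leave open whether an amine, a carboxylic acid or a longer chain at this place would keep the number high.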